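This account rests on a few compounds, and the source may have more. Where it says the series, first, only, none or still open, it means among the compounds named here.

Working notes on the series. Among the compounds with values here, in a functional assay on T-24 cells (Homo sapiens) for antiproliferative activity, read by MTT assay, with a stated time of 72 h (on this read-out lower numbers stand for stronger inhibition and higher numbers for weaker inhibition), compound 1 (`N=C(NC(=N)NC1CCCC1)Nc1ccc(C(F)(F)F)cc1`) gives 3700 nM as the lowest number so far. Compound 2 (`CC(C)CNC(=N)NC(=N)Nc1ccc(F)cc1F`) gives 40800 nM and compound 3 (`CC(C)NC(=N)NC(=N)Nc1ccc(F)c(F)c1`) gives 45000 nM in the same test. Compound 2 stands second highest of the three numbers, within the scatter of compound 3 and beyond the scatter of compound 1.

The next compound is compound 4 (`N=C(NC(=N)NC1CCCC1)Nc1ccc(F)cc1F`), which differs from compound 2 as follows (cyclopentyl in place of isobutyl on an amine nitrogen), that is, cyclopentyl in place of isobutyl on an amine nitrogen. Within the data shown here, no measured pair isolates this change. Among the measured compounds shown here, the only measured compound with cyclopentyl is compound 1 at 3700 nM with trifluoromethyl where compound 4 has its fluorines, so only part of the gap between compound 1 and compound 2 can be expected to carry over. The expectation in this assay is therefore a move towards a lower number, of moderate size and possibly not far beyond the scatter. The expected step is a 2.3-fold lower number from compound 2 to compound 4 (0.36 log units; beyond the scatter) as an estimate. For compound 4 the estimated value is 18000 nM with an expected range from 6000 nM to 45000 nM in this test.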

Compound 4, half-maximal inhibitory concentration: 37800 nM
Estimate against measurement, compound 4: 2.1-fold (0.32 log units) below; low and high end bracket the measured number.
By their numbers in this assay, from the lowest: compound 1; then compounds 4, 2 and 3 (each within the scatter of the next).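

In this assay, cyclopentyl in place of isobutyl on an amine nitrogen gives a 1.1-fold lower number from compound 2 to compound 4 (0.03 log units; within the scatter), which is within the scatter. With the fluorines of these two compounds in place, this amine nitrogen therefore takes a five-membered ring of carbon in place of the open branched chain with no change in the read-out that can be told from scatter. Cyclopentyl alone does not go with the low number seen so far: with trifluoromethyl where the fluorines stand, compound 1 gives 3700 nM, whereas compound 4 gives 37800 nM, and nothing measured here explains the result.

From the compounds shown here alone, it remains open whether a linear hexyl chain, a benzyl group or a cyclohexyl ring on the same amine nitrogen would also leave the number where it is. A compound with isobutyl and trifluoromethyl would show whether the same exchange is also without effect on the number with trifluoromethyl in place, and would give a comparison with compound 1 that differs in one place only.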